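Swapping the group on a sulfonamide nitrogen

This account rests on a few compounds, and the source may have more. Where it says the series, first, only, none or still open, it means among the compounds named here.

Among the measured compounds shown here, in a functional assay (CEM-VLB cells, Homo sapiens) for antiproliferative activity, read by sulforhodamine B assay, with a stated time of 48 h (on this read-out lower numbers stand for stronger inhibition and higher numbers for weaker inhibition), compound 2 (`Cc1ccc(C)c(NS(=O)(=O)c2ccc(N3CCNC3=O)cc2)c1`) gives 120 nM, the lower of the two numbers so far, while compound 1 (`Cc1cccc(NS(=O)(=O)c2ccc(N3CCNC3=O)cc2)c1`) gives 370 nM on the same core. Compound 3 (`O=C1NCCN1c1ccc(S(=O)(=O)Nc2cccc(Cl)c2)cc1`) carries 3-chlorophenyl in place of 2,5-dimethylphenyl on a sulfonamide nitrogen. For the measured compounds named here, the one measured step bearing on this is modest: a 3.1-fold lower number from compound 1 to compound 2 (0.49 log units; beyond the scatter) came with methyl in place of hydrogen on an aromatic carbon. With the 2,5-dimethylphenyl gone, a return toward compound 1 at 370 nM is expected. The estimated change is a 2.5-fold higher number from compound 2 to compound 3 (0.40 log units; beyond the scatter) in this assay (toward weaker inhibition). The estimate for compound 3 is 300 nM (expected range 110 nM to 800 nM).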

Compound 3, half-maximal inhibitory concentration: 170 nM
Estimate against measurement, compound 3: 1.8-fold (0.25 log units) above; the range from low to high includes it.
By their numbers in this assay, from the lowest: compounds 2 and 3 (each within the scatter of the next); then compound 1.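

In this assay, 3-chlorophenyl in place of 2,5-dimethylphenyl on the sulfonamide nitrogen gives a 1.4-fold higher number from compound 2 to compound 3 (0.15 log units; within the scatter) and so leaves the two groups indistinguishable here. Chloro in place of methyl on an aromatic carbon gives a 2.2-fold lower number from compound 1 to compound 3 (0.34 log units; beyond the scatter) and shows that adding a methyl is not the only single change that lowers the number from compound 1. Nothing shown here offers a reason for either step. Going by these compounds, whether a methoxy group or an amine on this phenyl ring would give a similar number remains open, as does the effect of replacing the ring with a saturated one such as cyclohexyl.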